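This account rests on a few compounds, and the source may have more. Where it says the series, first, only, none or still open, it means among the compounds named here.

Compound 1 `Cc1cccc(-c2n[nH]cc2N2CCCNCC2)c1` is a pyrazole-linked diazepane bearing a methyl-substituted phenyl ring, and in an assay on isolated protein for binding affinity to 5-hydroxytryptamine receptor 3A (Homo sapiens) (on this read-out lower numbers stand for stronger inhibition and higher numbers for weaker inhibition), compound 1 gives 816 nM. Among the three compounds measured in this assay, compound 1 shows the highest number, yet none of its gaps to the others is larger than the usual scatter. Its nearest neighbour, compound 2 `Cc1ccc(-c2n[nH]cc2N2CCCNCC2)cc1`, gives 744 nM in this assay, and the two values cannot be told apart. The furthest, compound 3 `Clc1ccc(-c2n[nH]cc2N2CCCNCC2)cc1`, gives 498 nM in this assay, again within the scatter of compound 1.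

Compound 4 `Fc1cccc(-c2n[nH]cc2N2CCCNCC2)c1` differs from compound 1 by a single exchange: fluoro in place of methyl on an aromatic carbon. Among the measured compounds shown here, no measured step replaces a methyl by a fluoro, so the closest precedent is the exchange of methyl for chloro, which produced a 1.5-fold lower number from compound 2 to compound 3 (0.17 log units; within the scatter). For the measured compounds named here, that step stayed within the scatter, and nothing among the measured compounds suggests that a one-atom halogen substitution moves the number appreciably.

On that basis compound 4 is expected to remain close to compound 1, the estimated step being a 1.1-fold lower number from compound 1 to compound 4 (0.05 log units; within the scatter). The expected value of compound 4 in this assay is therefore 720 nM, with a range from 360 nM to 1450 nM.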

Compound 4, inhibition constant: 656 nM
The estimate for compound 4 lay 1.1-fold (0.04 log units) above the measured number, and the stated range covers the measured number.
By their numbers in this assay, from the lowest: compounds 3, 4, 2 and 1 (each within the scatter of the next).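

At this place on the six-membered aromatic ring, meta to a large group, the exchange of methyl for fluoro gives a 1.2-fold lower number from compound 1 to compound 4 (0.09 log units; within the scatter) in this assay. Among the compounds shown here, this is the first direct reading at this place, since the only earlier step, a 1.5-fold lower number from compound 2 to compound 3 (0.17 log units; within the scatter), joined two compounds that carry no group here. The new step shows that fluoro can stand in for methyl at this place without the number leaving the scatter, although with only these two steps, both within the scatter, the data show no effect of either exchange and support no wider pattern, and no measurement is available that could explain the result.

From the compounds shown here alone, what an amine, a carboxylic acid or a longer chain such as butyl would do at this place remains open, as does the number for a plain hydrogen there, which would show whether the methyl or fluoro contributes anything at all. Also open, going by these compounds, is whether a change to the shared core, rather than to this one substituent, would move the number beyond the scatter.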